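A few compounds are considered here, and "the series" means these few. Any claim that something is new, unique, unknown or untested is made for them only; others in the source may bear on it.

Measured so far in an ADME assay on 184B5 cells (Homo sapiens) for cytotoxicity, read by MTT assay, with a stated time of 72 h; a lower number here means a stronger inhibitor of growth, a higher number a weaker inhibitor of growth:
- compound 1, `CCCCOC(=O)Nc1ccc([Se]C#N)cc1`: 5300 nM
- compound 2, `Cc1ccc(OC(=O)Nc2ccc([Se]C#N)cc2)cc1`: 4400 nM
- compound 3, `N#C[Se]c1ccc(NC(=O)Oc2ccc(Cl)cc2)cc1`: 5600 nM

All three compounds share the same core and differ only in the group carried on the carbamate side. In this assay the number for compound 3 is the largest of the three, yet its gaps to compound 1 and to compound 2 are both within the usual scatter, so the three compounds cannot be told apart on the numbers shown.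

Within the data shown here, the one step that compares two measured compounds differing in a single place is a 1.3-fold higher number from compound 2 to compound 3 (0.10 log units; within the scatter) — a change of substituent on the distal aromatic carbon that left the number essentially where it was.

Compound 4, `N#C[Se]c1ccc(NC(=O)Oc2ccccc2)cc1`, has not been measured yet. It differs from compound 3 by hydrogen in place of chloro on an aromatic carbon. Among the measured compounds shown here, the only step bearing on this is the one from compound 2 to compound 3, which exchanged one substituent for another at the same aromatic carbon without a change beyond the scatter. For the measured compounds named here, removing the substituent altogether is a further change at that carbon, and nothing among the measured compounds points to a direction for it. The expectation for compound 4 is therefore no step beyond the scatter, a 1.1-fold lower number from compound 3 to compound 4 (0.03 log units; within the scatter), with compound 4 estimated at 5200 nM and a range from 2600 nM to 10400 nM.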

Compound 4, concentration for 50% growth inhibition: 400 nM
Beside the measured number, compound 4's estimate is 13-fold (1.11 log units) above it; the whole stated range lies above it.
By their numbers in this assay, from the lowest: compound 4; then compounds 2, 1 and 3 (each within the scatter of the next).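

In this assay the unsubstituted aromatic carbon, para to a large group, stands apart from both substituted ones: the change to hydrogen gives a 14-fold lower number from compound 3 to compound 4 (1.15 log units; beyond the scatter) and also an 11-fold lower number from compound 2 to compound 4 (1.04 log units; beyond the scatter), whereas exchanging methyl for chloro at that same carbon gave only a 1.3-fold higher number from compound 2 to compound 3 (0.10 log units; within the scatter). Among these compounds, then, the sharp change at this carbon comes with hydrogen and with neither of the two substituents, and an aromatic ring on the carbamate oxygen is not enough by itself: replacing butyl with phenyl gives a 13-fold lower number from compound 1 to compound 4 (1.12 log units; beyond the scatter), yet compound 2 and compound 3 also carry a ring there and show no such step. Nothing measured in this set accounts for the step.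

From the compounds shown here alone, whether the step is tied to hydrogen itself or merely to the absence of methyl and chloro remains open, and a fluoro, methoxy or amino group at the same carbon would bear on that. Also open, going by these compounds, is how far substituents on the other carbons of this ring, or a longer chain in place of butyl, would move the number.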